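The compounds below may be only part of what the source reports. "The series", "measured", "known", "first", "only" and "open" are said of these compounds alone.

Measured so far:
compound 1 `CN(C(=S)SCc1ccc(C(=O)Nc2ccccc2N)cc1)c1cccnc1` — 70.5%
compound 2 `CCN(Cc1ccncc1)C(=S)SCc1ccc(C(=O)Nc2ccccc2N)cc1` — 77.7%

Compound 2 gives the higher of the two numbers in a functional assay on HeLa cells (Homo sapiens) for antiproliferative activity, read by CCK-8 assay, with a stated time of 72 h, tested at 8 uM (on this read-out lower numbers stand for a weaker effect and higher numbers for a stronger effect at the one concentration tested), yet its separation from compound 1, a number 7.2 percentage points higher from compound 1 to compound 2 (within the scatter), lies within the scatter, so the two read as level. Compound 3 `CN(Cc1cccnc1)C(=S)SCc1ccc(C(=O)Nc2ccccc2N)cc1` carries the change (methyl((pyridin-3-yl)methyl)amino in place of ethyl((pyridin-4-yl)methyl)amino on a thiocarbonyl carbon). Among the compounds with values here, the one measured step, a number 7.2 percentage points higher from compound 1 to compound 2 (within the scatter), also alters this amine and moved nothing beyond the scatter, so no shift beyond the scatter is expected here either. Compound 3 is therefore estimated at 74% with a range of 60% to 86%, the expected step being a number 3.7 percentage points lower from compound 2 to compound 3 (within the scatter).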

Compound 3, a percentage reported as inhibition, at one concentration (the size of the read-out at that concentration, not a potency): 68.7%
Beside the measured number, compound 3's estimate is 5.3 percentage points above it, and the stated range covers the measured number.
By their numbers in this assay, from the lowest: compounds 3, 1 and 2 (each within the scatter of the next).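

Replacing ethyl((pyridin-4-yl)methyl)amino with methyl((pyridin-3-yl)methyl)amino on a thiocarbonyl carbon gives a number 9 percentage points lower from compound 2 to compound 3 (within the scatter) in this assay. Within the data shown here, the single change of (pyridin-3-yl)methyl in place of pyridin-3-yl on an amide-type nitrogen gives a number 1.8 percentage points lower from compound 1 to compound 3 (within the scatter), so all three amines at this position read as level. No available evidence bears on this result.

Open, going by these compounds, is whether a morpholine or piperidine on the thiocarbonyl carbon, with no pyridine ring, would also read level with these three.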